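The compounds below may be only part of what the source reports. "The series", "measured", "known", "first", "only" and "open" are said of these compounds alone.

Working notes on the series, read in a functional assay on MDA-MB-231 cells (Homo sapiens) for cytotoxicity, read by MTT assay, with a stated time of 72 h; a lower number here means a stronger inhibitor, a higher number a weaker inhibitor. Compound 1 `COc1ccc(NC(=O)CN2CCN(c3nnc(Cc4ccncc4)c4ccccc34)CC2)cc1OC` gives 100 nM, compound 2 `O=C(CN1CCN(c2nnc(Cc3ccncc3)c3ccccc23)CC1)Nc1ccc(F)c(Cl)c1` gives 4 nM and compound 3 `O=C(CN1CCN(c2nnc(Cc3ccncc3)c3ccccc23)CC1)Nc1c(F)cccc1F` gives 1900 nM, the highest number of the three. Compound 4 `Cc1cccc(Cl)c1NC(=O)CN1CCN(c2nnc(Cc3ccncc3)c3ccccc23)CC1` is the next case: 2-chloro-6-methylphenyl in place of 2,6-difluorophenyl on an amide-type nitrogen.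

All measured steps change this same place, and all are large: a 25-fold lower number from compound 1 to compound 2 (1.40 log units; beyond the scatter), a 19-fold higher number from compound 1 to compound 3 (1.28 log units; beyond the scatter) and a 480-fold higher number from compound 2 to compound 3 (2.68 log units; beyond the scatter). Among the compounds with values here, none makes this exact exchange, so they show only that values here can move far in either direction. Compound 2 also carries chlorine, but within a different group, which gives only a weak pull towards a lower number. A moderate move in that direction is expected, far smaller than the largest measured step, with wide uncertainty.

The expected step is a 3.2-fold lower number from compound 3 to compound 4 (0.50 log units; beyond the scatter). Compound 4 is estimated at 600 nM, with an expected range of 70 nM to 4000 nM.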

Compound 4, half-maximal inhibitory concentration: 2670 nM
Compound 4: middle estimate off by 4.5-fold (0.65 log units), on the low side; measured number inside the range.
By their numbers in this assay, from the lowest: compound 2; then compound 1; then compounds 3 and 4 (each within the scatter of the next).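

In this assay, chlorine and methyl in place of the two fluorines leave the value within the scatter (a 1.4-fold higher number from compound 3 to compound 4 (0.15 log units; within the scatter)), so 2-chloro-6-methylphenyl and 2,6-difluorophenyl on the amide-type nitrogen cannot be told apart here. Compound 4 stays far from the other two (a 670-fold higher number from compound 2 to compound 4 (2.82 log units; beyond the scatter); a 27-fold higher number from compound 1 to compound 4 (1.43 log units; beyond the scatter)), which places compound 3 and compound 4 at the high end of these four compounds, and none of the four goes against this. Nothing at hand gives a reason for this grouping.

Going by these compounds, it remains open whether a phenyl carrying only the chlorine or only the methyl would read like compound 4 or like compound 2. Also open, on these data alone, is whether an amine or a carboxylic acid on this phenyl would keep a value near that of compound 2.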